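The source may report more compounds than this note shows. Statements on the series, on what has been measured and on what is new or still open speak of the compounds shown alone.

Measured compounds in a functional assay on HeLa cells (Homo sapiens) for cytotoxicity; a higher number here means a weaker inhibitor, a lower number a stronger inhibitor: compound 1 `C=CCOc1ccc2c(c1)C(=O)C=CC2=O` gives 27200 nM; compound 2 `O=C1C=C(Oc2ccco2)C(=O)c2ccccc21` gives 37000 nM; compound 3 `O=C1C=CC(=O)c2cc(OCc3ccccc3)ccc21` gives 16800 nM.

Compound 1 stands second highest of the three numbers in this assay, with compound 2 nearest and compound 3 furthest, both within the scatter. Compound 4 `CS(=O)(=O)Oc1ccc2c(c1)C(=O)C=CC2=O` differs from compound 1 by methylsulfonyl in place of allyl on an oxygen on an aromatic ring. For the measured compounds named here, the only measured step at this oxygen is a 1.6-fold lower number from compound 1 to compound 3 (0.21 log units; within the scatter), which swaps one carbon group for another and stays within the scatter. Nothing measured bears on replacing allyl by methylsulfonyl, so no step beyond the scatter is expected in this assay. For compound 4 the estimate is 27000 nM, range 9000 nM to 80000 nM, a step of a 1.0-fold lower number from compound 1 to compound 4 (0.00 log units; within the scatter) expected from compound 1, with the range left wide.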

Compound 4, half-maximal inhibitory concentration: 17700 nM
Estimate against measurement, compound 4: 1.5-fold (0.18 log units) above; measured number inside the range.
By their numbers in this assay, from the lowest: compounds 3, 4, 1 and 2 (each within the scatter of the next, the first and the last beyond it).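

The oxygen on an aromatic ring now carries methylsulfonyl as well as carbon groups, and in this assay this change gives a 1.5-fold lower number from compound 1 to compound 4 (0.19 log units; within the scatter) even though the entering group brings two hydrogen-bond acceptors and allyl brings none. Compounds 1, 3 and 4 therefore lie within the scatter of one another at this oxygen, so the swaps seen here do not separate them. No supporting data bear on why this change leaves the number within the scatter.

Still open, as far as these compounds go, is whether an amine or a carboxylic acid on a longer chain at this oxygen would give a step beyond the scatter. From the compounds shown here alone, the free hydroxyl at this position also remains open as a reference point for the series.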